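From hydroxy to ethyl on the side chain

A few compounds are considered here, and "the series" means these few. Any claim that something is new, unique, unknown or untested is made for them only; others in the source may bear on it.

In a functional assay on cells (Homo sapiens) for antiproliferative activity, read by MTT assay, with a stated time of 48 h (on this read-out lower numbers stand for stronger inhibition and higher numbers for weaker inhibition), compound 1 (`CCN(CC)CCn1c(N)c(-c2nc3ccccc3[nH]2)c2nc(C#N)c(C#N)nc21`) gives 25400 nM and compound 2 (`CN1CCN(CCn2c(N)c(-c3nc4ccccc4[nH]3)c3nc(C#N)c(C#N)nc32)CC1`) gives 9110 nM as measured numbers. Compound 3 (`N#Cc1nc2c(-c3nc4ccccc4[nH]3)c(N)n(CCO)c2nc1C#N`) reads > 50000 nM and this is a limit of the assay, not a number. Compound 4 (`CCCCn1c(N)c(-c2nc3ccccc3[nH]2)c2nc(C#N)c(C#N)nc21`) differs from it in one place (ethyl in place of hydroxy on a saturated chain carbon, two bonds along the chain from an aromatic nitrogen), with ethyl in place of hydroxy on a saturated chain carbon, two bonds along the chain from an aromatic nitrogen. Going by the values given here, two measured steps touch that place (an at least 1.9-fold higher number from compound 1 to compound 3 (0.29 log units; that floor lies within the scatter)) and (an at least 5.4-fold higher number from compound 2 to compound 3 (0.73 log units; beyond the scatter)), but neither brings in ethyl, so they guide only loosely. Compound 1 at 25400 nM shows that a chain without hydroxy can give a number here. A modest move to a lower number is therefore expected (an at least 1.7-fold lower number from compound 3 to compound 4 (0.25 log units; that floor lies within the scatter)) in this assay for this change. Compound 4 is estimated at 28000 nM within a range from 10000 nM to 50000 nM in this assay.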

Compound 4, half-maximal inhibitory concentration: > 50000 nM
Compound 4: only a limit was reported (the forecaster's own chance of this, stated with the estimate: 35%); middle value at least 1.7-fold (0.25 log units) away from the limit.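

In this assay compound 4 gives a limit of the assay and not a number, as compound 3 does, so the step between these two cannot be read. Butyl in place of the chains ending in an amine gives an at least 5.4-fold higher number from compound 2 to compound 4 (0.73 log units; beyond the scatter) and an at least 1.9-fold higher number from compound 1 to compound 4 (0.29 log units; that floor lies within the scatter) and only the first of these floors clears the scatter. Among these four compounds, only the two chains ending in an amine give measured numbers, and the two others sit at the limit: the limit of > 50000 nM in this assay, at which 2 of the 4 values shown sit.

Still open, going by these compounds, is whether a chain ending in a morpholine ring, a primary amine or a carboxylic acid would give a measured number. On these data alone, how far compound 3 and compound 4 lie beyond the limit also remains unknown.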